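Moving the chlorine on the pendant phenyl: compound 4

The source may hold more compounds than are shown below. What is called first, only, known or untested is meant among the compounds shown, and "the series" means these compounds.

Compound 1 `O=C1/C(=C\c2c(Cl)cccc2Cl)c2ccccc2N1c1c(Cl)cccc1Cl` gives 100 ug/mL in a functional assay on HuTu80 cells (Homo sapiens) for cytotoxicity, read by MTT assay, with a stated time of 72 h; a higher number here means that more compound is needed for the effect, a lower number that less compound is needed.
Compound 2 `O=C1/C(=C\c2ccccc2Cl)c2ccccc2N1c1c(Cl)cccc1Cl` gives > 100 ug/mL in this assay, which is a limit of the assay, not a number.
Compound 3 `O=C1/C(=C\c2cccc(Cl)c2)c2ccccc2N1c1c(Cl)cccc1Cl` gives 7 ug/mL in this assay.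

Compound 3 has the lowest number of the two numbers shown; the step of a 14-fold lower number from compound 1 to compound 3 (1.15 log units; beyond the scatter) separates it from the nearest, and compound 2 sits at the limit (the limit of > 100 ug/mL in this assay, at which 1 of the 3 values shown sits). Compound 4 `O=C1/C(=C\c2ccc(Cl)cc2)c2ccccc2N1c1c(Cl)cccc1Cl` differs from compound 3 by 4-chlorophenyl in place of 3-chlorophenyl on a double-bonded chain carbon bound to a double-bonded ring carbon. The steps that touch this ring, a 14-fold lower number from compound 1 to compound 3 (1.15 log units; beyond the scatter) and an at least 14-fold lower number from compound 2 to compound 3 (1.15 log units; beyond the scatter), were both large, but neither covers a 4-chlorophenyl, so no direction is fixed. In this assay compound 4 is expected near compound 3, with the step of a 1.4-fold higher number from compound 3 to compound 4 (0.15 log units; within the scatter) likely within the scatter. The estimate for compound 4 is 10 ug/mL, in the range 3 ug/mL to 40 ug/mL.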

Compound 4, concentration for half-maximal effect: 6 ug/mL
Compound 4: the middle estimate sits 1.7-fold (0.22 log units) above what was measured; the range from low to high includes it.
By their numbers in this assay, from the lowest: compounds 4 and 3 (each within the scatter of the next); then compound 1.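

On the double-bonded chain carbon, 4-chlorophenyl and 3-chlorophenyl cannot be told apart in this assay, with a 1.2-fold lower number from compound 3 to compound 4 (0.07 log units; within the scatter). The new compound also repeats the large gaps to the other two groups, 2-chlorophenyl and 2,6-dichlorophenyl, with an at least 16-fold lower number from compound 2 to compound 4 (1.22 log units; beyond the scatter) and a 17-fold lower number from compound 1 to compound 4 (1.22 log units; beyond the scatter). Compound 2 stands at a limit of the assay, not a number: the limit of > 100 ug/mL in this assay, at which 1 of the 4 values shown sits.

Going by these compounds, what an unsubstituted phenyl would give at this place stays open. So does whether a methoxy group or an amine could take the place of the chlorine in 4-chlorophenyl.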